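Cyclohexyl in place of cyclopentyl on compound 2

The compounds below may be only part of what the source reports. "The series", "measured", "known", "first", "only" and "open" are said of these compounds alone.

Compound 1 `Cn1cc(Nc2nn(Cc3ccc(C(=O)NC4CCCCC4)cc3)c(=O)c3ccccc23)cn1`: 6800 nM
Compound 2 `Cc1noc(C)c1-c1nn(Cc2ccc(C(=O)NC3CCCC3)cc2)c(=O)c2ccccc12`: > 100000 nM (a limit, not a number)

In a functional assay on A549 cells (Homo sapiens) for antiproliferative activity, read by MTT assay, with a stated time of 72 h (a higher number here means a weaker inhibitor, a lower number a stronger inhibitor), compound 2 stands at the limit of > 100000 nM in this assay, at which 1 of the 2 values shown sits. Its real position in this assay is therefore not known. Among the measured compounds shown here, the only numerical value belongs to compound 1, at 6800 nM.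

Compound 3 `Cc1noc(C)c1-c1nn(Cc2ccc(C(=O)NC3CCCCC3)cc2)c(=O)c2ccccc12` is compound 2 with cyclohexyl in place of cyclopentyl on an amide-type nitrogen. For the measured compounds named here, no measured pair isolates this change, so there is no direct guide to the size of its effect. A modest shift towards a stronger inhibitor is expected, and compound 3 may equally return only a limit. The expected change is an at least 2.0-fold lower number from compound 2 to compound 3 (0.30 log units; that floor lies within the scatter). For compound 3 the estimated value is 50000 nM, with an expected range of 12000 nM to 100000 nM.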

Compound 3, half-maximal inhibitory concentration: > 100000 nM
Compound 3 ended at the assay's limit; the forecaster's own chance of this, stated with the estimate: 50%; middle value at least 2.0-fold (0.30 log units) from the limit.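

In this assay compound 3 gives > 100000 nM, a limit and not a number, so cyclohexyl on the amide-type nitrogen leaves this 3,5-dimethyl-1,2-oxazol-4-yl compound at the limit. The step from cyclopentyl to cyclohexyl cannot be read, because both compounds carrying these groups sit at the limit: the limit of > 100000 nM in this assay, at which 2 of the 3 values shown sit.

Among the compounds shown here, compound 1 and compound 3 now form a pair differing in one place, and 3,5-dimethyl-1,2-oxazol-4-yl in place of (1-methyl-1H-pyrazol-4-yl)amino on an aromatic carbon gives an at least 14-fold higher number from compound 1 to compound 3 (1.16 log units; beyond the scatter), the one readable step.

As far as these compounds go, whether cyclopentyl and cyclohexyl differ on a compound that returns a number remains open. Also open, from the compounds shown here alone, is whether the amino nitrogen or the 1-methylpyrazole part of compound 1 matters more, and how a phenylamino or morpholine group on that aromatic carbon would read.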